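The source may hold more compounds than are shown below. What is called first, only, known or untested is meant among the compounds shown, and "the series" means these compounds.

Compound 1 `[O-][S+](Cc1ccccc1)c1nnc(-c2cccs2)o1` in a functional assay on HUVEC cells (Homo sapiens) for inhibition, read by ELISA (a higher number here means a weaker inhibitor, a lower number a stronger inhibitor), gives 7000 nM.
Compound 2 `CCCc1nnc([S+]([O-])Cc2ncc(C)c(OC)c2C)o1` in this assay gives 10000 nM.
Compound 3 `COc1c(C)cnc(C[S+]([O-])c2nnc(-c3ccccc3)o2)c1C` in this assay gives 7000 nM.

Compound 3 stands level with compound 1 at the digits shown, the two together giving the lowest of the three numbers. Its nearest neighbour is compound 1, with no change at the digits shown, and its furthest is compound 2, which differs by a 1.4-fold lower number from compound 2 to compound 3 (0.15 log units; within the scatter), a step from propyl to phenyl that stays within the scatter.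

Compound 4 `COc1c(C)cnc(C[S+]([O-])c2nnc(-c3ccccc3O)o2)c1C` is the next compound and differs from compound 3 in one place: hydroxy in place of hydrogen on an aromatic carbon. Cut one bond further out, the change reads phenyl to 2-hydroxyphenyl, the hydroxy sitting on a six-membered aromatic ring of carbon only, ortho to a large group.

Within the data shown here, no measured step involves a hydroxy on this ring, so none bears directly on the change. Among the measured compounds shown here, the one step available, from propyl to phenyl, was within the scatter, and the three numbers overall sit close together. Compound 4 is therefore expected to show a step of about a 1.2-fold lower number from compound 3 to compound 4 (0.07 log units; within the scatter) in this assay, which is no change beyond the scatter. Compound 4 is estimated at 6000 nM, with a range from 2000 nM to 20000 nM.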

Compound 4, half-maximal inhibitory concentration: 10000 nM
For compound 4 the middle estimate is 1.7-fold (0.22 log units) below the measured one, within the range that was stated.
By their numbers in this assay, from the lowest: compounds 1, 3, 2 and 4 (each within the scatter of the next).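

In this assay, hydroxy in place of hydrogen on an aromatic carbon of the six-membered ring, ortho to a large group, gives a 1.4-fold higher number from compound 3 to compound 4 (0.15 log units; within the scatter), so this first reading of a hydroxy at this position does not separate it from hydrogen. Replacing propyl with 2-hydroxyphenyl gives no change at the digits printed from compound 2 to compound 4 (within the scatter), and with a 1.4-fold lower number from compound 2 to compound 3 (0.15 log units; within the scatter) this means that propyl, phenyl and 2-hydroxyphenyl cannot be told apart at this place in the shared core within this assay. No evidence is available that bears on this result.

The compounds shown leave open whether a methoxy, an amine or a carboxylic acid in place of the hydroxy on this ring, or hydroxy on another carbon of the ring, would give a step beyond the scatter. They also leave open whether a longer chain than propyl at the same place would do so, since every step read here at this place lies within the scatter.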